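Phenyl in Place of Benzyl on a Fused Core

A few compounds are considered here, and "the series" means these few. Any claim that something is new, unique, unknown or untested is made for them only; others in the source may bear on it.

Measured so far in a physicochemical assay for acid dissociation:
compound 1 `COc1cccc(Oc2ccc3c(NCCCNCc4cc(F)ccc4OC)ccnc3c2)c1` gives 9.28
compound 2 `COc1cccc(CNCCCNc2ccnc3cc(Cc4ccccc4)ccc23)c1O` gives 9.47
compound 3 `Fc1ccc(Cc2ccc3c(NCCCNCc4ccco4)ccnc3c2)c(Cl)c1` gives 9.47

Compound 2 stands level with compound 3 at the digits shown, and the two together give the highest of the three numbers; compound 1 lies a little lower, but within the scatter, so no order among the three can be read from these values. Among the measured compounds shown here, no pair of measured compounds differs in only one place, so no measured step is available to lean on.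

Compound 4 `COc1cccc(CNCCCNc2ccnc3cc(-c4ccccc4)ccc23)c1O` differs from compound 2 in one place: phenyl in place of benzyl on an aromatic carbon. With nothing measured on such a change, the step of a number 0.02 log units lower from compound 2 to compound 4 (within the scatter) is expected to be none beyond the scatter. For compound 4 the estimate in this assay is 9.45, with a range from 9.1 to 9.8.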

Compound 4, acid dissociation constant: 9.47
Compound 4: the middle estimate sits 0.02 log units below what was measured, and the stated range covers the measured number.
By their numbers in this assay, from the lowest: compounds 1, 2, 3 and 4 (each within the scatter of the next).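

In this assay, among the compounds shown here, phenyl in place of benzyl on this aromatic carbon gives no change at the digits printed from compound 2 to compound 4 (within the scatter), the only step here between compounds that differ in one place. For the compounds shown here, at this position, then, the read-out does not register this exchange, something the earlier compounds, with no such pair among them, could not show. No measurement bearing on the reason for this result is available.

From the compounds shown here alone, whether an amine or a carboxylic acid on the phenyl ring would shift this number stays open. So does whether a longer chain at this position would do so, and whether the same exchange behaves alike with a different side chain.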